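The source may report more compounds than this note shows. Statements on the series, on what has been measured and on what is new or still open speak of the compounds shown alone.

Compound 1 `O=[N+]([O-])c1ccc(C(c2c[nH]c3ccc(Br)cc23)c2c[nH]c3ccc(Br)cc23)cc1` gives 1500 nM in a functional assay on HeLa cells (Homo sapiens) for inhibition, read by MTT assay, with a stated time of 48 h; a lower number here means a stronger inhibitor, a higher number a weaker inhibitor.
Compound 2 `CCCCCCCC(c1c[nH]c2ccc(Br)cc12)c1c[nH]c2ccc(Br)cc12` gives 1300 nM.
Compound 3 `O=[N+]([O-])c1ccc(C(c2c[nH]c3ccc([N+](=O)[O-])cc23)c2c[nH]c3ccc([N+](=O)[O-])cc23)cc1` gives only a limit of the assay, > 100000 nM.

Compound 4 `CCCCCCCC(c1c[nH]c2ccc([N+](=O)[O-])cc12)c1c[nH]c2ccc([N+](=O)[O-])cc12` has not yet been measured in this assay. Compounds 1 and 2 share a core and differ by one change, (heptyl in place of 4-nitrophenyl on a saturated chain carbon bound to two aromatic carbons), which made a 1.2-fold lower number from compound 1 to compound 2 (0.06 log units; within the scatter). Compound 3 and compound 1 have different cores; the difference between the two cores is not broken down here. The same change, (heptyl in place of 4-nitrophenyl on a saturated chain carbon bound to two aromatic carbons), leads from compound 3 to compound 4. Because compound 3 sits at the limit of > 100000 nM in this assay, at which 1 of the 3 values shown sits, a move of the size seen between compounds 1 and 2 is expected to leave compound 4 at that limit as well, so the step that the limit leaves unreadable from compound 3 to compound 4 is expected to be small. Compound 4 is therefore estimated at 150000 nM, with a likely range from 50000 nM to 500000 nM.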

Compound 4, half-maximal inhibitory concentration: 35000 nM
For compound 4 the middle estimate is 4.3-fold (0.63 log units) above the measured one; measured number outside the range, below it.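

In this assay, putting heptyl in place of 4-nitrophenyl gives an at least 2.8-fold lower number from compound 3 to compound 4 (0.45 log units; beyond the scatter). Compound 3 gives > 100000 nM, which is a limit of the assay and not a number. The full size of this step therefore stays unknown, and the data neither show that the change carries over unaltered from one core to the other nor that it behaves differently: the same change on two cores in this assay, a 1.2-fold lower number (0.06 log units; within the scatter) from compound 1 to compound 2 and an at least 2.8-fold lower number (0.45 log units; beyond the scatter) from compound 3 to compound 4; the limit leaves it open whether they differ

The compounds shown leave open how a longer chain, or a chain ending in an amine or a carboxylic acid, would behave in place of heptyl. A group of that kind with a readable value on both cores would allow a direct comparison of the two cores.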